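Chloroacetamide Step Repeated on the Free-Thiol Core

The compounds below may be only part of what the source reports. "The series", "measured", "known", "first", "only" and "open" are said of these compounds alone.

Compound 1 `CCCSc1nnc(COc2ccccc2C2=NOC(c3ccc(Cl)cc3Cl)C2)n1NC(C)=O` gives 128 ug/mL in an ADME assay (MDM cells, Homo sapiens) for cytotoxicity, read by resazurin assay, with a stated time of 3 days; a higher number here means a weaker inhibitor, a lower number a stronger inhibitor.
Compound 2 `CCCSc1nnc(COc2ccccc2C2=NOC(c3ccc(Cl)cc3Cl)C2)n1NC(=O)CCl` gives 28.7 ug/mL in this assay.
Compound 3 `CC(=O)Nn1c(S)nnc1COc1ccccc1C1=NOC(c2ccc(Cl)cc2Cl)C1` gives 1.3 ug/mL in this assay.

Of the three measured compounds, compound 3 shows the lowest number in this assay; compound 2 and compound 1 both stand well above it. Two single changes connect the set. The first, (chloro in place of hydrogen on a saturated chain carbon bound to a carbonyl carbon), produced a 4.5-fold lower number from compound 1 to compound 2 (0.65 log units; beyond the scatter). The second, (hydrogen in place of propyl on a sulfur), produced a 98-fold lower number from compound 1 to compound 3 (1.99 log units; beyond the scatter).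

Compound 4 `O=C(CCl)Nn1c(S)nnc1COc1ccccc1C1=NOC(c2ccc(Cl)cc2Cl)C1` is not yet measured in this assay. It carries the same kind of change that turned compound 1 into compound 2, now made on the core of compound 3: chloro in place of hydrogen on a saturated chain carbon bound to a carbonyl carbon. The place of the change reads the same in both pairs, while the two cores differ by hydrogen in place of propyl on a sulfur.

Because a 4.5-fold lower number from compound 1 to compound 2 (0.65 log units; beyond the scatter) was a modest step, compound 4 is expected to move from compound 3 by a step of similar size, a 2.9-fold lower number from compound 3 to compound 4 (0.46 log units; beyond the scatter), with the range widened since the step has been seen only once and compound 3 already sits low. The estimate for compound 4 is 0.45 ug/mL, expected to lie between 0.15 ug/mL and 1.8 ug/mL.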

Compound 4, half-maximal inhibitory concentration: 3.2 ug/mL
Estimate against measurement, compound 4: 7.1-fold (0.85 log units) below; measured number above the stated range.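

In this assay, chloro in place of hydrogen on a saturated chain carbon bound to a carbonyl carbon did not carry over from the core of compound 1 to the core of compound 3: the new result is a 2.5-fold higher number from compound 3 to compound 4 (0.39 log units; beyond the scatter), which runs against the earlier step, and the two steps differ: the same change on two cores in this assay, a 4.5-fold lower number (0.65 log units; beyond the scatter) from compound 1 to compound 2 and a 2.5-fold higher number (0.39 log units; beyond the scatter) from compound 3 to compound 4, 11-fold (1.04 log units) apart, beyond the scatter of two such steps
Hydrogen in place of propyl on a sulfur lowered the number on both cores, here giving a 9.0-fold lower number from compound 2 to compound 4 (0.95 log units; beyond the scatter), but the size of that step depended on which amide group the core carried: the same change on two cores in this assay, a 98-fold lower number (1.99 log units; beyond the scatter) from compound 1 to compound 3 and a 9.0-fold lower number (0.95 log units; beyond the scatter) from compound 2 to compound 4, 11-fold (1.04 log units) apart, beyond the scatter of two such steps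
The two changes therefore did not act independently in these four compounds, although this does not show why, and a single pair on each core cannot predict the step on any further core.

The compounds shown leave open whether the reversal is specific to chloro or would also appear with bromo or a methoxy group at the same place. They also leave open whether a shorter chain on the sulfur, such as methyl, would behave like propyl or like hydrogen.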